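Replacing pyrrolidinyl with carbamoylpiperidinyl on the acyl chain

The compounds below may be only part of what the source reports. "The series", "measured", "known", "first", "only" and "open" are said of these compounds alone.

The series shares one core, carried in compound 1 `Cc1ccc(C(=O)N2N=C(c3cc4ccccc4oc3=O)CC2c2ccccc2)cc1`, which bears a 4-methylphenyl group on its carbonyl carbon. In a functional assay on MGC-803 cells (Homo sapiens) for cytotoxicity, read by MTT assay, with a stated time of 48 h (on this read-out lower numbers stand for stronger inhibition and higher numbers for weaker inhibition), compound 1 gives 31300 nM. Compound 2 `CCC(=O)N1N=C(c2cc3ccccc3oc2=O)CC1c1ccccc1` carries an ethyl group there instead, and in this assay compound 2 gives 5300 nM; the change is a 5.9-fold lower number from compound 1 to compound 2 (0.77 log units; beyond the scatter). Compound 3 `O=C(CN1CCCC1)N1N=C(c2cc3ccccc3oc2=O)CC1c1ccccc1` is a further variant of the same core, and in this assay compound 3 is reported only as "not active" (no number reported), so no single number places it against compound 1 or compound 2. Compound 4 `NC(=O)C1CCN(CC(=O)N2N=C(c3cc4ccccc4oc3=O)CC2c2ccccc2)CC1` differs from compound 3 in one place: 4-carbamoylpiperidin-1-yl in place of pyrrolidin-1-yl on a saturated chain carbon bound to a carbonyl carbon. Within the data shown here, none of the measured steps bears on this change; the only step, that between compound 1 and compound 2, concerns the group directly on the carbonyl carbon rather than a substituent beyond it, and compound 3 itself has no number from which a step could be counted. What the data show is that compound 3, the nearest relative of compound 4, returned no number in this assay. The expectation for compound 4 in this assay is therefore weak inhibition, with a fair chance that again no number is returned, and the estimate is 60000 nM with a range from 15000 nM to 200000 nM.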

Compound 4, half-maximal inhibitory concentration: 21500 nM
Compound 4: middle estimate off by 2.8-fold (0.45 log units), on the high side; the range from low to high includes it.
By their numbers in this assay, from the lowest: compound 2; then compounds 4 and 1 (each within the scatter of the next).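

With 4-carbamoylpiperidin-1-yl in place of pyrrolidin-1-yl on a saturated chain carbon bound to a carbonyl carbon, this position now yields a number in this assay, where compound 4 gives 21500 nM and compound 3 gave none, so the size of the step from compound 3 to compound 4 cannot be read. Placing 4-carbamoylpiperidin-1-yl in place of methyl on a saturated chain carbon bound to a carbonyl carbon gives a 4.1-fold higher number from compound 2 to compound 4 (0.61 log units; beyond the scatter), whereas (4-carbamoylpiperidin-1-yl)methyl in place of 4-methylphenyl on a carbonyl carbon gives a 1.5-fold lower number from compound 1 to compound 4 (0.16 log units; within the scatter), so this longer substituted chain falls short of the ethyl group but does not separate from the 4-methylphenyl group. No supporting measurement is available to explain either result.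

The compounds shown leave open whether the number for compound 4 goes with the six-membered ring or with the carbamoyl group, a question that plain piperidin-1-yl on the same carbon, or a carboxylic acid in place of the carbamoyl group, would address. They also leave open how an open-chain amine such as dimethylamino would behave at this position.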